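Working notes: trimethylsilyl replacing hexyl on the alkyne

The source may report more compounds than this note shows. Statements on the series, on what has been measured and on what is new or still open speak of the compounds shown alone.

In a functional assay on A-375 cells (Homo sapiens) for antiproliferative activity, read by trypan blue exclusion, with a stated time of 48 h, tested at 5 uM (a lower number here means a stronger effect, a higher number a weaker effect of the compound at the concentration tested), compound 3 `CCCCCCC#Cc1cccc(S(=O)(=O)Nc2cccc(-c3csc(NC(C)=O)n3)c2)c1` gives 1.2%, the lowest of the three numbers in hand. Compound 2 `CC(=O)Nc1nc(-c2cccc(NS(=O)(=O)c3ccc(C#CCCc4ccccc4)cc3)c2)cs1` gives 4.2%, within the scatter of compound 3, while compound 1 `C#Cc1ccc(S(=O)(=O)Nc2cccc(-c3csc(NC(C)=O)n3)c2)cc1` gives 38.3%, beyond the scatter above it. Compound 4 `CC(=O)Nc1nc(-c2cccc(NS(=O)(=O)c3cccc(C#C[Si](C)(C)C)c3)c2)cs1` is not yet measured in this assay. Its difference from compound 3 is a group of 4 heavy atoms (3 carbon, 1 silicon; no ring) in place of a group of 6 heavy atoms (6 carbon; no ring), on a triple-bonded carbon. For the measured compounds named here, the only measured step that touches the triple-bonded carbon is a number 34.1 percentage points lower from compound 1 to compound 2 (beyond the scatter), a large move downward when a group is placed where hydrogen stood; between compound 2 and compound 3 the change of that group from phenethyl to hexyl left the two values within the scatter. Compound 4 keeps a substituted alkyne, so the number for compound 4 is expected to stay low, with only a small step of a number 6.8 percentage points higher from compound 3 to compound 4 (within the scatter) upward allowed because compound 3 gives 1.2% and cannot go much lower. Compound 4 is estimated at 8%, between 1% and 28%.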

Compound 4, a percentage reported as activity, at one concentration (the size of the read-out at that concentration, not a potency): < 1%
Compound 4: no number, only a limit (the forecaster's own chance of this, stated with the estimate: 5%); at least 7 percentage points between middle value and limit.
By their numbers in this assay, from the lowest: compounds 3 and 2 (each within the scatter of the next); then compound 1. At a limit, below all of these: compound 4.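

In this assay compound 4 gives < 1%, which is a limit of the assay and not a number. The step, a number at least 0.2 percentage points lower from compound 3 to compound 4 (that floor lies within the scatter), shows that on this triple-bonded carbon the hexyl chain of 6 heavy atoms can give way to trimethylsilyl, a group of 4 heavy atoms that contains silicon, with no rise in the read-out, so the low reading does not depend on hexyl itself. How far the two compounds truly lie apart cannot be read, and the order between them stays unsettled at this end of the scale: the limit of < 1% in this assay, at which 1 of the 4 values shown sits.

The compounds shown leave open whether an amine or a carboxylic acid on the end of the alkyne, or a chain longer than hexyl, would keep the read-out this low. A single concentration also gives no potency for compound 3 or compound 4.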